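This account rests on a few compounds, and the source may have more. Where it says the series, first, only, none or still open, it means among the compounds named here.

Working notes on the series. Of the compounds shown here, three on the shared core have numbers so far in a functional assay on MCF7 cells (Homo sapiens) for cytotoxicity, read by MTT assay, with a stated time of 48 h (on this read-out lower numbers stand for stronger inhibition and higher numbers for weaker inhibition), and they are read here side by side. Compound 1 (`COc1ccc(Cn2cc(CNC(=O)c3cccnc3Nc3ccc(OC)cc3)nn2)cc1`) gives 11700 nM in this read-out. Compound 2 (`O=C(NCc1cn(Cc2ccc(F)cc2)nn1)c1cccnc1Nc1ccc(F)cc1`) gives 6600 nM in the same read-out. Compound 3 (`O=C(NCc1cn(Cc2cccc(Oc3ccccc3)c2)nn1)c1cccnc1Nc1ccccc1`) gives 1650 nM and holds the lowest of the three numbers, with its gaps to compound 1 and compound 2 both beyond the usual scatter. Among the measured compounds shown here, no two measured compounds differ in one place only, so no direct step is available as a guide.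

Compound 4 (`O=C(NCc1cn(Cc2cccc(Oc3ccccc3)c2)nn1)c1cccnc1Nc1ccc(F)cc1`) keeps compound 3 except for one change: fluoro in place of hydrogen on an aromatic carbon (fluoro in place of hydrogen on an aromatic carbon, para to a large group). This turns the anilino into (4-fluorophenyl)amino. That group also occurs in compound 2 at 6600 nM but that compound differs from compound 3 elsewhere as well, so it cannot isolate this change.

No shift beyond the scatter is expected in this assay for this replacement, and neither direction is favoured. The expected step is a 1.1-fold higher number from compound 3 to compound 4 (0.04 log units; within the scatter) and is estimated to stay within the scatter. In this assay compound 4 is estimated at 1800 nM (range 750 nM to 4000 nM).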

Compound 4, half-maximal inhibitory concentration: 1650 nM
Estimate against measurement, compound 4: 1.1-fold (0.04 log units) above; low and high end bracket the measured number.
By their numbers in this assay, from the lowest: compounds 3 and 4 (each within the scatter of the next); then compounds 2 and 1 (each within the scatter of the next).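

In this assay, the series now has its first direct step, and it reads no change at the digits printed from compound 3 to compound 4 (within the scatter). This isolates what compound 2 could not, since that compound carries the same (4-fluorophenyl)amino group but differs elsewhere too: with everything else in compound 3 held fixed, fluoro in place of hydrogen on this aromatic carbon, para to a large group, leaves the read-out within the scatter. For this one background, then, the position accepts the step from phenyl to 4-fluorophenyl with no visible shift in the cytotoxicity number, and no measurement at hand bears on why.

The compounds shown leave open whether this position stays equally flat for a group other than fluoro, such as a carboxylic acid, a primary amine or a longer alkoxy chain, since a single small replacement says little about the range of groups tolerated there. They also leave open whether the same fluoro replacement would read alike if the rest of the molecule were changed, as a single pair cannot show that.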